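The source may report more compounds than this note shows. Statements on the series, on what has been measured and on what is new or still open speak of the compounds shown alone.

Going by the values given here, compound 2 `O=C(O)Cc1sc(C(c2ccc(F)cc2)c2ccc(F)cc2)nc1-c1cccc(F)c1` gives the lower of the two numbers known so far in an in vitro functional assay on HEK285-7 cells for antagonist activity at prostaglandin D2 receptor 2 (Homo sapiens), read by BRET and beta-arrestin recruitment (a lower number here means a stronger inhibitor, a higher number a weaker inhibitor), at 18 nM. Compound 1 `O=C(O)Cc1sc(C2COc3ccccc3O2)nc1-c1ccc(Cl)cc1` gives 2000 nM in this assay, a much higher number. Compound 3 `O=C(O)Cc1sc(C(c2ccc(F)cc2)c2ccc(F)cc2)nc1-c1ccnc(Cl)c1` differs from compound 2 in one place: 2-chloropyridin-4-yl in place of 3-fluorophenyl on an aromatic carbon. Among the compounds with values here, no measured pair shows this particular change, so its effect can only be guessed. A step of a 1.7-fold higher number from compound 2 to compound 3 (0.22 log units; within the scatter) is expected, within the scatter or only slightly beyond it toward a weaker inhibitor. Compound 3 is estimated at 30 nM in this assay, with a range from 10 nM to 100 nM.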

Compound 3, half-maximal inhibitory concentration: 39 nM
The estimate for compound 3 lay 1.3-fold (0.11 log units) below the measured number, and the stated range covers the measured number.
By their numbers in this assay, from the lowest: compound 2; then compound 3; then compound 1.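

In this assay, replacing 3-fluorophenyl with 2-chloropyridin-4-yl on this aromatic carbon next to the ring nitrogen gives a 2.2-fold higher number from compound 2 to compound 3 (0.34 log units; beyond the scatter), a modest step toward a weaker inhibitor. This position therefore tolerates a six-membered aromatic ring with 1 hetero atom and 1 hydrogen-bond acceptor at only a modest cost in this series. Nothing available explains this shift. On these data alone, the step changes the ring nitrogen and the chlorine together, so their separate contributions remain open. A 3-chlorophenyl or an unsubstituted pyridin-4-yl group at this position would separate them.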